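Bromo in Place of Methyl: Expected Cytotoxicity of Compound 3

A few compounds are considered here, and "the series" means these few. Any claim that something is new, unique, unknown or untested is made for them only; others in the source may bear on it.

Measured compounds:
compound 1 `CC(C)(C)OC(=O)Nc1ncc(C(Oc2ccc3cc(Br)ccc3c2)c2ccc(Cl)cc2)s1`: > 50000 nM
compound 2 `Cc1ccc(C(=O)Nc2ncc(C(Oc3ccc4cc(Br)ccc4c3)c3ccc(Cl)cc3)s2)cc1`: "not toxic" (no number reported)

Of the compounds shown here, two have been tested in an ADME assay on HepG2 2.2.15 cells (Homo sapiens) for cytotoxicity; on this read-out higher numbers stand for lower toxicity in this test and lower numbers for higher toxicity in this test. Compound 1 gives > 50000 nM in this assay, and this figure is a limit of the assay rather than a number. For compound 2 the result is recorded only as "not toxic" (no number reported), so no single number tells where compound 2 stands. Among the measured compounds shown here, the one further value shown for this series is a limit: the limit of > 50000 nM in this assay, at which 1 of the 2 values shown sits. Neither compound therefore anchors a numerical scale for this assay.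

Compound 3 `O=C(Nc1ncc(C(Oc2ccc3cc(Br)ccc3c2)c2ccc(Cl)cc2)s1)c1ccc(Br)cc1` differs from compound 2 in one place: bromo in place of methyl on an aromatic carbon. For the measured compounds named here, no step between two measured compounds is available, so nothing here shows how such a change moves the read-out. In this assay the step from compound 2 to compound 3 is expected to stay within the usual scatter, with no clear direction, and a further limit seems the most probable outcome. Compound 3 is estimated at 50000 nM in this assay, with a range from 20000 nM to 100000 nM.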

Compound 3, half-maximal cytotoxic concentration: > 50000 nM
Compound 3 was reported as a limit; the forecaster's own chance of this, stated with the estimate: 75%; the middle value sits exactly at the limit.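

In this assay compound 3 gives > 50000 nM, a limit of the assay and not a number. Compound 1 stands at the same limit, so no step can be read between compound 1 and compound 3: the limit of > 50000 nM in this assay, at which 2 of the 3 values shown sit.

The compounds shown leave open at what concentration any of them becomes cytotoxic, and whether bromo in place of methyl moves the read-out at all.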